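The compounds below may be only part of what the source reports. "The series", "measured", "known", "first", "only" and "open" are said of these compounds alone.

Compound 1 `O=C(O)c1cccc2c(/N=N/c3c(O)cc(S(=O)(=O)O)c4ccccc34)c(O)ccc12` gives < 5% in an assay on BaF3 cells with thrombopoietin receptor (Homo sapiens) as the target, read by a luciferase reporter (on this read-out lower numbers stand for smaller maximal responses and higher numbers for larger maximal responses), which is a limit of the assay rather than a number.
Compound 2 `O=S(=O)(O)c1ccc(/N=N/c2c(O)ccc3ccccc23)c2ccccc12` gives < 5%, again a limit.
Compound 3 `Oc1ccc2ccccc2c1/N=N/c1c(O)ccc2ccccc12` gives < 5%, once more a limit.

All three measured compounds sit at one point: the limit of < 5% in this assay, at which 3 of the 3 values shown sit. Compound 3 thus stands exactly where the other measured compounds stand, and its value is a limit, not a number. Compound 4 `O=[N+]([O-])c1cc(O)c(/N=N/c2c(O)ccc3ccccc23)c2ccccc12` differs from compound 3 in one place: nitro in place of hydrogen on an aromatic carbon. Going by the values given here, no step between measured compounds has been recorded, and no measured compound carries a nitro group, so nothing here shows the weight of this change. Because the limit of < 5% in this assay, at which 3 of the 3 values shown sit, covers all three measured compounds, the step that the limit leaves unreadable from compound 3 to compound 4 in this assay is expected to be none beyond the scatter. Compound 4 is therefore expected to give 3%, between 0% and 12%, most likely again only as a limit.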

Compound 4, largest response reached (reported as efficacy), in percent of the reference or control that the assay uses: < 5%
Compound 4 ended at the assay's limit; the forecaster's own chance of this, stated with the estimate: 80%; the middle value is on the limit's open side.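

No step can be read between compound 3 and compound 4: both values are limits, not numbers, and the effect of nitro in place of hydrogen stays hidden. The compounds shown leave open which structures, if any, give a response in this assay that rises clear of the limit.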